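A few compounds are considered here, and "the series" means these few. Any claim that something is new, unique, unknown or untested is made for them only; others in the source may bear on it.

Compound 1 `CCC(=O)N(C)c1ccc2[nH]c(-c3n[nH]c4ccccc34)cc2n1` in a functional assay on HCT-116 cells (Homo sapiens) for antiproliferative activity, read by MTT assay, with a stated time of 72 h (a lower number here means a stronger inhibitor, a higher number a weaker inhibitor), gives 10800 nM.
Compound 2 `CN(C(=O)CCc1ccccc1)c1ccc2[nH]c(-c3n[nH]c4ccccc34)cc2n1` in this assay gives 11200 nM.
Compound 3 `CN(c1ccc2[nH]c(-c3n[nH]c4ccccc34)cc2n1)S(=O)(=O)c1ccc(Br)cc1` in this assay gives 9850 nM.

Compound 3 carries the lowest of the three numbers, but the steps of a 1.1-fold lower number from compound 1 to compound 3 (0.04 log units; within the scatter) and a 1.1-fold lower number from compound 2 to compound 3 (0.06 log units; within the scatter) both lie within the scatter, so the three compounds cannot be told apart. Compound 4 `CN(c1ccc2[nH]c(-c3n[nH]c4ccccc34)cc2n1)S(=O)(=O)c1cccc([N+](=O)[O-])c1` differs from compound 3 only in the group on the sulfonyl sulfur: 3-nitrophenyl in place of 4-bromophenyl on a sulfonyl sulfur. Among the compounds with values here, no measured step changes that part; the steps that swap the whole group on the ring nitrogen, a 1.1-fold lower number from compound 1 to compound 3 (0.04 log units; within the scatter) and a 1.1-fold lower number from compound 2 to compound 3 (0.06 log units; within the scatter), were small. The step of a 1.0-fold lower number from compound 3 to compound 4 (0.02 log units; within the scatter) is therefore expected to stay within the scatter. For compound 4 the estimate in this assay is 9500 nM, within a range from 4500 nM to 20000 nM.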

Compound 4, half-maximal inhibitory concentration: 13600 nM
The estimate for compound 4 lay 1.4-fold (0.16 log units) below the measured number; low and high end bracket the measured number.
By their numbers in this assay, from the lowest: compounds 3, 1, 2 and 4 (each within the scatter of the next).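

Within the data shown here, the first change on the aryl group attached to the sulfonyl sulfur, in this assay, gives a 1.4-fold higher number from compound 3 to compound 4 (0.14 log units; within the scatter). Exchanging 4-bromophenyl for 3-nitrophenyl, which adds two hydrogen-bond acceptors, therefore does not separate these sulfonamides, and all four compounds remain indistinguishable. No measured evidence accounts for this result.

Still open, as far as these compounds go, is whether an amine or a carboxylic acid on that phenyl ring would move the number beyond the scatter. So is the outcome of replacing the whole ring on sulfur with a methyl group.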